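A Benzyl Group Swap in a Small Cytotoxic Series

A few compounds are considered here, and "the series" means these few. Any claim that something is new, unique, unknown or untested is made for them only; others in the source may bear on it.

Measured in a functional assay on K562 cells (Homo sapiens) for cytotoxicity, read by MTT assay, with a stated time of 48 h; a higher number here means a weaker inhibitor, a lower number a stronger inhibitor:
compound 1 `O=C(CN[C@H]1CCN(S(=O)(=O)Cc2ccccc2)C1)N1CCN(Cc2cccc(Cl)c2)CC1` - 8600 nM
compound 2 `O=C(CN[C@H]1CCN(S(=O)(=O)Cc2ccccc2)C1)N1CCN(Cc2ccc(Cl)cc2Cl)CC1` - 4300 nM

Compound 2 lies within the usual scatter of compound 1, so these two cannot be ranked. For the measured compounds named here, the next compound, compound 3 `O=C(CN[C@H]1CCN(S(=O)(=O)Cc2ccccc2)C1)N1CCN(Cc2c(F)cccc2Cl)CC1`, has no measurement yet. It keeps the shared core and alters one group: 2-chloro-6-fluorophenyl in place of 2,4-dichlorophenyl on a saturated chain carbon bound to an amine nitrogen in a ring. Going by the values given here, only one measured step bears on this change: a 2.0-fold lower number from compound 1 to compound 2 (0.30 log units; within the scatter). It involved a different swap at the same place, 2,4-dichlorophenyl in place of 3-chlorophenyl. Among the compounds with values here, one small step sets no trend, and no measured compound carries fluorine. The expected change in this assay is therefore nothing beyond the scatter, estimated as a 1.2-fold higher number from compound 2 to compound 3 (0.07 log units; within the scatter). For compound 3 the estimated value is 5000 nM, with an expected range of 1800 nM to 14000 nM.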

Compound 3, half-maximal inhibitory concentration: 65800 nM
The estimate for compound 3 lay 13-fold (1.12 log units) below the measured number, and the stated range ends below it.
By their numbers in this assay, from the lowest: compounds 2 and 1 (each within the scatter of the next); then compound 3.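

The group on this saturated chain carbon matters far more in this assay than the earlier pair suggested: the swap to 2-chloro-6-fluorophenyl gives a 15-fold higher number from compound 2 to compound 3 (1.18 log units; beyond the scatter) even though the entering and leaving groups have the same count of heavy atoms and neither carries a charge. Compound 3 also stands apart from the 3-chlorophenyl compound, with a 7.7-fold higher number from compound 1 to compound 3 (0.88 log units; beyond the scatter) and so has the highest number of the three, while compound 1 and compound 2 remain unranked. Nothing measured here explains why this swap costs so much.

Compound 3 brings in fluorine and also changes the substitution pattern, so the compounds shown cannot say which of the two matters. A 2,6-dichlorophenyl or a 2-chloro-4-fluorophenyl group at this place would separate them.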